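Hydrogen in place of chloro on compound 1

The compounds below may be only part of what the source reports. "The series", "measured", "known", "first", "only" and "open" are said of these compounds alone.

Measured in an ADME assay on the whole organism (Canis lupus familiaris, strain Beagle) for metabolic stability, read by LC-MS, with a stated time of 7 h; a higher number here means that the compound lasts longer, a lower number that the compound disappears faster:
compound 1 `CNC(=O)c1cc(C(=O)N[C@H]2CC[C@H](O)CC2)c([C@@H](C)c2cccc(Cl)c2)o1`: 3.1 h
compound 2 `CNC(=O)c1cc(C(=O)N[C@H]2CC[C@H](O)CC2)n([C@@H](C)c2ccccc2)n1`: 9 h

Of these two, compound 1 stands lowest, and its distance to compound 2 lies beyond the scatter. Compound 3 `CNC(=O)c1cc(C(=O)N[C@H]2CC[C@H](O)CC2)c([C@@H](C)c2ccccc2)o1` comes from compound 1 through a single change, hydrogen in place of chloro on an aromatic carbon. Within the data shown here, no measured pair shows this change alone, so the expectation rests on little. In this assay the expected result is a 1.1-fold higher number from compound 1 to compound 3 (0.05 log units; within the scatter), which is no step beyond the scatter. Compound 3 is estimated at 3.5 h, with an expected range from 1.7 h to 7 h.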

Compound 3, half-life: 5.2 h
Estimate against measurement, compound 3: 1.5-fold (0.17 log units) below; low and high end bracket the measured number.
By their numbers in this assay, from the lowest: compounds 1, 3 and 2 (each within the scatter of the next, the first and the last beyond it).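

Hydrogen in place of chloro on an aromatic carbon, 3-chlorophenyl to phenyl, gives in this assay a 1.7-fold higher number from compound 1 to compound 3 (0.22 log units; within the scatter) and so shows that at this position the chloro can go without a step beyond the scatter. This is the first pair shown that differs in this one place, and no measurement here offers an explanation for the result. From the compounds shown here alone, whether fluoro, methyl or methoxy at this place would give a different half-life stays open, as does the effect of chloro on the phenyl of compound 2.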